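Oxadiazole Hydrazones on HepG2: A Catechol Replaces a Nitro Group

A few compounds are considered here, and "the series" means these few. Any claim that something is new, unique, unknown or untested is made for them only; others in the source may bear on it.

Compound 1 `O=C(CSc1nnc(-c2ccncc2)o1)N/N=C/c1ccc([N+](=O)[O-])cc1`: 17900 nM
Compound 2 `O=C(CSc1nnc(-c2ccncc2)o1)N/N=C/c1ccccc1F`: 16000 nM
Compound 3 `O=C(CSc1nnc(-c2ccncc2)o1)N/N=C/c1ccccc1[N+](=O)[O-]`: 24700 nM

The three measured compounds were tested in a functional assay on HepG2 cells (Homo sapiens) for cytotoxicity, read by MTT assay, with a stated time of 48 h; on this read-out lower numbers stand for stronger inhibition and higher numbers for weaker inhibition. Compound 1 stands second highest of the three numbers, but every step among them is within the scatter: a 1.1-fold lower number from compound 1 to compound 2 (0.05 log units; within the scatter), a 1.4-fold higher number from compound 1 to compound 3 (0.14 log units; within the scatter) and a 1.5-fold higher number from compound 2 to compound 3 (0.19 log units; within the scatter). Compound 4 `O=C(CSc1nnc(-c2ccncc2)o1)N/N=C/c1ccc(O)c(O)c1` is not yet measured; it differs from compound 1 in one place, (3,4-dihydroxyphenyl in place of 4-nitrophenyl on a carbon with a double bond to nitrogen). Among the compounds with values here, no measured step exchanges a nitro group for a hydroxyl, so the three steps bear on it only by showing that the aryl changes tried so far left the read-out unchanged. A step from compound 1 to compound 4 of a 1.1-fold higher number from compound 1 to compound 4 (0.03 log units; within the scatter) is therefore expected, none beyond the scatter. For compound 4 the estimate is 19000 nM, in the range 7000 nM to 50000 nM.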

Compound 4, half-maximal inhibitory concentration: 760 nM
Beside the measured number, compound 4's estimate is 25-fold (1.40 log units) above it; the measured number lies below the stated range.
By their numbers in this assay, from the lowest: compound 4; then compounds 2, 1 and 3 (each within the scatter of the next).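

In this assay this position proves able to move the read-out, since the 3,4-dihydroxyphenyl group gives a 24-fold lower number from compound 1 to compound 4 (1.37 log units; beyond the scatter) and a 33-fold lower number from compound 3 to compound 4 (1.51 log units; beyond the scatter) and also a 21-fold lower number from compound 2 to compound 4 (1.32 log units; beyond the scatter) in a step beyond the scatter. The earlier aryl changes at this carbon had all stayed within the scatter, so the step holds against the 4-nitrophenyl, 2-nitrophenyl and 2-fluorophenyl groups alike. Nothing available explains why the read-out moves so far. On these data alone, whether both hydroxyl groups are needed stays open, and a single hydroxyl or a methoxy group here would bear on that question.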